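The compounds below may be only part of what the source reports. "The series", "measured", "known", "first", "only" and "open" are said of these compounds alone.

Measured compounds:
compound 1 `CCN(CC)c1ccc(/C=C/C(=O)c2ccc(OC)c3c2OC(C)(C)C=C3)cc1`: 670 nM
compound 2 `COc1ccc(C(=O)/C=C/c2ccc(OC)c(OC)c2OC)c2c1C=CC(C)(C)O2`: > 10000 nM

Among the measured compounds shown here, of these two results in a functional assay on SW-620 cells (Homo sapiens) for antiproliferative activity, read by MTT assay, with a stated time of 24 h (a lower number here means a stronger inhibitor, a higher number a weaker inhibitor), compound 1 carries the only one that is a number. The value of compound 2 is a limit of the assay and not a number (the limit of > 10000 nM in this assay, at which 1 of the 2 values shown sits). Compound 3 `COc1ccc(C(=O)/C=C/c2ccc(Cl)cc2)c2c1C=CC(C)(C)O2` comes from compound 1 by one change: chloro in place of diethylamino on an aromatic carbon. For the measured compounds named here, no measured pair here differs in a single place, so nothing anchors the size of this step. The change is expected to weaken the compound, by a step of a 4.5-fold higher number from compound 1 to compound 3 (0.65 log units; beyond the scatter) that goes beyond the usual scatter. Compound 3 is therefore estimated at 3000 nM, with a range from 800 nM to 10000 nM.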

Compound 3, half-maximal inhibitory concentration: > 10000 nM
Compound 3: only a limit was reported; the forecaster's own chance of this, stated with the estimate: 30%; middle value at least 3.3-fold (0.52 log units) from the limit.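

In this assay, the change to chloro on this aromatic carbon gives the first step from a single change: an at least 14-fold higher number from compound 1 to compound 3 (1.17 log units; beyond the scatter). Compound 3 gives > 10000 nM, which is a limit and not a number, so the step has no upper end: the limit of > 10000 nM in this assay, at which 2 of the 3 values shown sit. The group at this position can therefore decide whether any activity is read at all, and here diethylamino keeps it while chloro does not.

From the compounds shown here alone, what remains open is whether the nitrogen or its two ethyl chains matter more. Dimethylamino, a ring amine such as pyrrolidine, or a plain butyl chain at this position could separate the two.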